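Methyl for hydrogen on the chain carbon, two cores

The compounds below may be only part of what the source reports. "The series", "measured", "known", "first", "only" and "open" are said of these compounds alone.

Compound 1 `CC(C)C(NC(=O)NO)C(=O)NC1CCCC1` gives 33400 nM in a functional assay on HEp-2 cells (Homo sapiens) for inhibition; on this read-out higher numbers stand for weaker inhibition and lower numbers for stronger inhibition. Compound 2 `CC(C)C(NC(=O)n1nnc2ccccc21)C(=O)NC1CCCC1` gives 60300 nM in this assay, and compound 3 `CCC(C)C(NC(=O)n1nnc2ccccc21)C(=O)NC1CCCC1` gives 55700 nM. The difference between the core of compound 1 and the core of compound 2 is not broken down here; their values lie within the scatter of each other.

From compound 2 to compound 3 the change is methyl in place of hydrogen on a saturated chain carbon, three bonds along the chain from an amide-type nitrogen and a carbonyl carbon, and it made a 1.1-fold lower number from compound 2 to compound 3 (0.03 log units; within the scatter).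

Compound 4 `CCC(C)C(NC(=O)NO)C(=O)NC1CCCC1` carries the same change on the core of compound 1: methyl in place of hydrogen on a saturated chain carbon, three bonds along the chain from an amide-type nitrogen and a carbonyl carbon. The place of the change is the same in both pairs.

Because a 1.1-fold lower number from compound 2 to compound 3 (0.03 log units; within the scatter) lay within the scatter, the step for compound 4 is expected to be a 1.1-fold lower number from compound 1 to compound 4 (0.05 log units; within the scatter). Compound 4 is estimated at 30000 nM, with a range from 15000 nM to 60000 nM.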

Compound 4, half-maximal inhibitory concentration: > 100000 nM
Compound 4 ended at the assay's limit; the forecaster's own chance of this, stated with the estimate: 5%; middle value at least 3.3-fold (0.52 log units) from the limit.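

Methyl in place of hydrogen on the saturated chain carbon does not carry over from one core to the other in this series: the same change on two cores in this assay, a 1.1-fold lower number (0.03 log units; within the scatter) from compound 2 to compound 3 and an at least 2.9-fold higher number (0.47 log units; beyond the scatter) from compound 1 to compound 4, at least 3.2-fold (0.51 log units) apart, beyond the scatter of two such steps

In this assay compound 4 gives > 100000 nM, which is a limit of the assay and not a number.

The change gives an at least 2.9-fold higher number from compound 1 to compound 4 (0.47 log units; beyond the scatter) on one core, against a 1.1-fold lower number from compound 2 to compound 3 (0.03 log units; within the scatter) on the other; this shows that the step depends on the core, but it gives neither the full size of the first step nor a reason for the gap, and one pair per core sets no rule for further cores.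

Open, from the compounds shown here alone, is how a longer chain or an amine at this same chain carbon would behave on the two cores. Also open, going by these compounds, is whether a smaller change there would keep a value within the range of the assay on the core of compound 1.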